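Swapping the Aryl Ring on a Kynurenine Monooxygenase Inhibitor

This account rests on a few compounds, and the source may have more. Where it says the series, first, only, none or still open, it means among the compounds named here.

Measured so far:
compound 1 `C[C@@H](Oc1cc2oc(=O)n(CCC(=O)O)c2cc1Cl)c1ccc(F)cn1` gives 25.1 nM in an assay on HEK293 cells for inhibition of kynurenine 3-monooxygenase (Homo sapiens), read by LC-MS, with a stated time of 20 h; a lower number here means a stronger inhibitor, a higher number a weaker inhibitor
compound 2 `Cc1ccc([C@@H](C)Oc2cc3onc(CCC(=O)O)c3cc2Cl)nn1` gives 3.16 nM in this assay

Compound 1 has the highest number of the two, and compound 2 sits well beyond the scatter below it. Compound 3 `C[C@@H](Oc1cc2oc(=O)n(CCC(=O)O)c2cc1Cl)c1ncccn1` keeps the core of compound 1 and changes only the ring on the side chain: pyrimidin-2-yl in place of 5-fluoropyridin-2-yl on a saturated chain carbon bound to an oxygen on an aromatic ring and a saturated chain carbon. Among the compounds with values here, no measured pair shows this exact change, so the step from compound 1 is expected to be small, with a slight rise in the number plausible. Compound 3 is estimated at 30 nM, within 10 nM to 100 nM, a step of a 1.2-fold higher number from compound 1 to compound 3 (0.08 log units; within the scatter).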

Compound 3, half-maximal inhibitory concentration: 3160 nM
Compound 3: middle estimate off by 110-fold (2.02 log units), on the low side; the measured number lies above the stated range.
By their numbers in this assay, from the lowest: compound 2; then compound 1; then compound 3.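

The ring on this saturated chain carbon matters far more than its small size suggests: pyrimidin-2-yl in place of 5-fluoropyridin-2-yl gives a 130-fold higher number from compound 1 to compound 3 (2.10 log units; beyond the scatter) on an otherwise unchanged compound. Nothing available explains this loss of potency.

This single change removes the fluorine and adds a second ring nitrogen together, so the compounds shown cannot tell which of the two matters. Within the data shown here, a plain pyridin-2-yl ring, carrying no fluorine and only one ring nitrogen, would separate these two differences.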